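A chloro on the phenylcarbamoyl ring of the series

The compounds below may be only part of what the source reports. "The series", "measured", "known", "first", "only" and "open" are said of these compounds alone.

Measured so far:
Compound 1 `CN(C)C(=O)c1cc2cnc(Nc3ccc(NC(=O)C4(C(=O)Nc5ccccc5)CC4)cc3)nc2n1C1CCCC1`, in a functional assay on OVCAR-5 cells (Homo sapiens) for inhibition, read by CCK-8 assay, with a stated time of 72 h, tested at 10 uM; a lower number here means less inhibition of growth, a higher number more inhibition of growth at the concentration tested: 77.1%
Compound 2 `CN(C)C(=O)c1cc2cnc(Nc3ccc(NC(=O)C4(C(=O)Nc5cccc(Cl)c5)CC4)cc3)nc2n1C1CCCC1`, in this assay: 88.1%

Compound 1 stands lowest of the two numbers in this assay; its nearest neighbour is compound 2, and the step of a number 11 percentage points higher from compound 1 to compound 2 (beyond the scatter) lies beyond the scatter. Compound 3 `CN(C)C(=O)c1cc2cnc(Nc3ccc(NC(=O)C4(C(=O)Nc5ccc(Cl)cc5)CC4)cc3)nc2n1C1CCCC1` differs from compound 1 by chloro in place of hydrogen on an aromatic carbon. Among the measured compounds shown here, the one measured step that bears on this move is a number 11 percentage points higher from compound 1 to compound 2 (beyond the scatter), which is the same exchange of chloro for hydrogen on an aromatic carbon of the same phenylcarbamoyl ring, only at another carbon of that ring. It gave a modest gain. For the measured compounds named here, with a single precedent, and no measured pair that separates one carbon of this ring from another, the expectation for compound 3 is a step of about the same size and direction, a number 8.9 percentage points higher from compound 1 to compound 3 (within the scatter), with the range widened to allow that the gain may not carry over fully. Compound 3 is therefore estimated at 86% in this assay, between 74% and 95%.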

Compound 3, percent growth inhibition at one concentration: 85.3%
For compound 3 the middle estimate is 0.7 percentage points above the measured one, within the range that was stated.
By their numbers in this assay, from the lowest: compounds 1, 3 and 2 (each within the scatter of the next, the first and the last beyond it).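

In this assay, chloro in place of hydrogen on the aromatic carbon para to a large group gives a number 8.2 percentage points higher from compound 1 to compound 3 (within the scatter), so this step alone cannot be told apart from no change, unlike a number 11 percentage points higher from compound 1 to compound 2 (beyond the scatter), the step to the 3-chlorophenyl analogue. The exchange of 3-chlorophenyl for 4-chlorophenyl gives a number 2.8 percentage points lower from compound 2 to compound 3 (within the scatter), so the two chloro placements are not separated by this read-out, and the phenylcarbamoyl ring accepts chloro at either carbon with no loss of growth inhibition at the concentration tested. Nothing at hand offers an explanation for these numbers.

From the compounds shown here alone, whether a methoxy, a nitrile or a dimethylamino group on this ring would give numbers like those of chloro remains open, as does the outcome of placing chloro on the remaining ring carbons or of putting a second chloro on the same ring. With growth inhibition read at a single concentration, these compounds also leave open whether full concentration-response curves would separate the 3-chlorophenyl and 4-chlorophenyl analogues.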